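Swapping methyl for bromo on the triazole-linked phenyl

The source may report more compounds than this note shows. Statements on the series, on what has been measured and on what is new or still open speak of the compounds shown alone.

Compound 1 `N#CC1=C(N)Oc2c(c3nc4ccccc4nc3c3ccccc23)C12C(=O)N(Cc1cnnn1-c1cccc(Cl)c1)c1ccccc12` gives 43600 nM in a functional assay on MCF7 cells (Homo sapiens) for antiproliferative activity, read by MTT assay, with a stated time of 48 h; a higher number here means a weaker inhibitor, a lower number a stronger inhibitor.
Compound 2 `CC(=O)Nc1ccc(-n2nncc2CN2C(=O)C3(C(C#N)=C(N)Oc4c3c3nc5ccccc5nc3c3ccccc43)c3ccccc32)cc1` gives only a limit of the assay in this assay, > 50000 nM.
Compound 3 `Cc1ccccc1-n1nncc1CN1C(=O)C2(C(C#N)=C(N)Oc3c(N)cc4nc5ccccc5nc4c32)c2ccccc21` gives only a limit of the assay in this assay, > 50000 nM.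

Compound 3 therefore stands at the top of what this assay can report: it shares (the limit of > 50000 nM in this assay, at which 2 of the 3 values shown sit), so only a weak inhibitor is indicated, with no exact number. Compound 4 `N#CC1=C(N)Oc2c(N)cc3nc4ccccc4nc3c2C12C(=O)N(Cc1cnnn1-c1ccccc1Br)c1ccccc12` is the new compound; it differs from compound 3 by bromo in place of methyl on an aromatic carbon. Within the data shown here, the one measured step that also changes the phenyl on the triazole nitrogen is an at least 1.1-fold higher number from compound 1 to compound 2 (0.05 log units; that floor lies within the scatter), which carried a weak compound to the limit. Nothing among the three measured compounds shows such a change on this phenyl making a compound stronger. A step of about a number no higher from compound 3 to compound 4 (the limit leaves the size open) is expected, that is, no change beyond the scatter. Compound 4 is thus expected to give roughly 50000 nM, somewhere between 25000 nM and 100000 nM, and most likely the assay will again report only a limit.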

Compound 4, half-maximal inhibitory concentration: 30700 nM
For compound 4 the middle estimate is 1.6-fold (0.21 log units) above the measured one, within the range that was stated.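

Bromo in place of methyl, on an aromatic carbon ortho to a large group, brings the read-out off the limit and gives an exact value. The step is an at least 1.6-fold lower number from compound 3 to compound 4 (0.21 log units; that floor lies within the scatter). Going by these compounds, how large the step truly is stays open because compound 3 sits at a limit of the assay: the limit of > 50000 nM in this assay, at which 2 of the 4 values shown sit.

The compounds shown do not tell whether a fluoro, methoxy or amino group at this same place would also give an exact value, or whether the result is particular to bromo. They also leave open whether 2-bromophenyl would give a similar result on the core of compound 1, and whether any change on this phenyl can bring the series much below the values seen here.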